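The source may hold more compounds than are shown below. What is called first, only, known or untested is meant among the compounds shown, and "the series" means these compounds.

Measured so far:
compound 1 `COc1cc(OCC(=O)Nc2cccc(NC(=O)c3ccc(N(C)C)cc3)c2)ccc1C=O`: 3740 nM
compound 2 `COc1ccc(C(=O)Nc2cccc(NC(=O)COc3ccc4c(=O)ccoc4c3)c2)cc1`: 18 nM
compound 3 `O=C(COc1ccc2c(=O)ccoc2c1)Nc1cccc(NS(=O)(=O)c2ccc(C(F)(F)F)cc2)c1`: > 10000 nM

In an assay on isolated protein for inhibition of Rho-associated protein kinase 1 (Homo sapiens), read by scintillation counting, radiometric assay and 33P incorporation, with a stated time of 40 min, in the presence of a further agent that is not named here (on this read-out lower numbers stand for stronger inhibition and higher numbers for weaker inhibition), compound 2 stands lowest of the two plain numbers, with compound 1 far weaker, well beyond the usual scatter. The value of compound 3 is a limit of this assay, not a number. Compound 4 `O=C(COc1ccc2c(=O)ccoc2c1)Nc1cccc(NC(=O)c2ccc(C(=O)O)cc2)c1` has not yet been measured. It differs from compound 2 in a single place: carboxy in place of methoxy on an aromatic carbon. Among the measured compounds shown here, no pair of measured compounds differs in only one place, so nothing here shows directly what such a change does, and the expectation rests on compound 2 alone. The step is expected to be a modest weakening, a 3.3-fold higher number from compound 2 to compound 4 (0.52 log units; beyond the scatter). Compound 4 is therefore estimated at 60 nM, in a range from 15 nM to 300 nM.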

Compound 4, half-maximal inhibitory concentration: 6890 nM
For compound 4 the middle estimate is 110-fold (2.06 log units) below the measured one, outside the stated range (above it).
By their numbers in this assay, from the lowest: compound 2; then compounds 1 and 4 (each within the scatter of the next). At a limit, above all of these: compound 3.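

In this assay, this position, para to a large group, proves able to decide the strength of inhibition: carboxy in place of methoxy gives a 380-fold higher number from compound 2 to compound 4 (2.58 log units; beyond the scatter). Among the compounds shown here, no earlier pair could show this, since none differed in one place alone. Little room remains for reading anything weaker at this position: the limit of > 10000 nM in this assay, at which 1 of the 4 values shown sits.

From the compounds shown here alone, whether this loss is particular to carboxy stays open. An amine, a hydroxy group or a methyl ester at the same place would show whether other groups fare as badly or keep the strength of compound 2.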